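The source may report more compounds than this note shows. Statements on the series, on what has been measured and on what is new or still open speak of the compounds shown alone.

In a functional assay on the whole organism (Sciatic nerve) for inhibition, with Rattus norvegicus as the target, with a stated time of 27 h (a lower number here means that less compound is needed, a higher number that more compound is needed for the effect), three compounds that share a core have been measured. Compound 1, `C[C@@H]1C[C@@](O)(CC(=O)O)c2cc(Cl)cc(Cl)c2O1`, gives 26.6 mg/kg in this assay. Compound 2, `Cc1cc(Cl)cc2c1O[C@H](C)C[C@@]2(O)CC(=O)O`, gives 49 mg/kg in this assay. Compound 3, `C[C@@H]1C[C@@](O)(CC(=O)O)c2cc([N+](=O)[O-])c(Cl)cc2O1`, gives 14.9 mg/kg in this assay, the lowest of the three numbers. The difference between the core of compound 1 and the core of compound 3 is not broken down here.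

Compound 1 and compound 2 differ in one place, (methyl in place of chloro on an aromatic carbon), and that change made a step of a 1.8-fold higher number from compound 1 to compound 2 (0.27 log units; within the scatter) in this assay.

Compound 4, `Cc1cc2c(cc1[N+](=O)[O-])[C@](O)(CC(=O)O)C[C@@H](C)O2`, has not been measured. It differs from compound 3 by methyl in place of chloro on an aromatic carbon. Within the data shown here, this is the same kind of change as the one from compound 1 to compound 2, but not the same: in compound 1 the leaving chloro sits ortho to a fused ring, meta to a chloro group and meta to a fused ring, whereas in compound 3 it sits ortho to a nitro group, meta to a fused ring and para to a fused ring.

For compound 4 a step of about a 1.8-fold higher number from compound 3 to compound 4 (0.26 log units; within the scatter) in this assay is expected, resting on the earlier step of a 1.8-fold higher number from compound 1 to compound 2 (0.27 log units; within the scatter) of the same kind of change. Compound 4 is therefore estimated at 27 mg/kg in this assay, with a range from 13 mg/kg to 55 mg/kg.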

Compound 4, dose for half-maximal effect: 35 mg/kg
Compound 4: middle estimate off by 1.3-fold (0.11 log units), on the low side; the measured number falls inside the stated range.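

Replacing chloro with methyl, ortho to a nitro group, gave a 2.3-fold higher number from compound 3 to compound 4 (0.37 log units; beyond the scatter) in this assay. Set beside the earlier case on the other core, the change points the same way on both cores, and the two steps cannot be told apart: the same change on two cores in this assay, a 1.8-fold higher number (0.27 log units; within the scatter) from compound 1 to compound 2 and a 2.3-fold higher number (0.37 log units; beyond the scatter) from compound 3 to compound 4, 1.3-fold (0.11 log units) apart, within the scatter of two such steps. Among these compounds, this supports carrying the change between these two cores as a rough guide, but it does not show why the number moves, and it rests on only one pair per core, with one step inside the scatter and only a modest one beyond it, so it does not establish that the same step would appear on any further core.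

The compounds shown leave open whether other groups in this place, such as fluoro, methoxy or an amine, would raise or lower the number in this assay, since only chloro and methyl are compared here. They also leave open whether the step would hold if the carboxylic acid were replaced by an ester or an amide.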